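Three Rings on the Same Chain, and a Fourth

The source may report more compounds than this note shows. Statements on the series, on what has been measured and on what is new or still open speak of the compounds shown alone.

Compound 1, `COc1cc2c(Nc3ccc(C#N)cc3)ncnc2cc1OCCCN1CCCC1`, gives 8080 nM in a functional assay on SH-SY5Y cells (Homo sapiens) for antiproliferative activity, read by MTT assay, with a stated time of 72 h; on this read-out lower numbers stand for stronger inhibition and higher numbers for weaker inhibition.
Compound 2, `COc1cc2c(Nc3ccc(C#N)cc3)ncnc2cc1OCCCN1CCCCC1`, gives 18800 nM in this assay.
Compound 3, `CCOC(=O)C1CCN(CCCOc2cc3ncnc(Nc4ccc(C#N)cc4)c3cc2OC)CC1`, gives 47200 nM in this assay.

All three share one core and differ only in the ring at the end of the chain. Among the three numbers, compound 2 stands second highest: compound 1 sits nearer, and compound 3 furthest. The steps run as a 2.3-fold higher number from compound 1 to compound 2 (0.37 log units; beyond the scatter) and a 2.5-fold higher number from compound 2 to compound 3 (0.40 log units; beyond the scatter).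

Compound 4, `COc1cc2c(Nc3ccc(C#N)cc3)ncnc2cc1OCCCN1CCN(C)CC1`, has not yet been measured. It differs from compound 2 as 4-methylpiperazin-1-yl in place of piperidin-1-yl on a saturated chain carbon, three bonds along the chain from an oxygen on an aromatic ring. Going by the values given here, no measured step makes this exact exchange. The two steps that touch compound 2 both change the ring at the end of the chain, and both gave modest rises in number, so this is a region where the ring is varied without large effects in this assay. A modest step in either direction, or none beyond the scatter, is the reasonable expectation.

Compound 4 is therefore expected to give about 15000 nM in this assay, within 6000 nM to 40000 nM, which is an expected step of a 1.3-fold lower number from compound 2 to compound 4 (0.10 log units; within the scatter).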

Compound 4, half-maximal inhibitory concentration: 13000 nM
Beside the measured number, compound 4's estimate is 1.2-fold (0.06 log units) above it; the range from low to high includes it.
By their numbers in this assay, from the lowest: compounds 1, 4 and 2 (each within the scatter of the next, the first and the last beyond it); then compound 3.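

In this assay, the new exchange puts 4-methylpiperazin-1-yl, with its second ring nitrogen and a methyl group, in place of piperidin-1-yl on the same saturated chain carbon, and the result is a 1.4-fold lower number from compound 2 to compound 4 (0.16 log units; within the scatter). So the earlier comparisons, which changed only the carbon ring size or added an ester, did not show that this ring can carry a second nitrogen with no change beyond the scatter. The same is true against the five-membered pyrrolidin-1-yl ring, with a 1.6-fold higher number from compound 1 to compound 4 (0.21 log units; within the scatter), whereas the ester-bearing ring remains apart, with a 3.6-fold lower number from compound 3 to compound 4 (0.56 log units; beyond the scatter), so these four compounds form a loose group of three rings and one exception.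

No measurement here explains why the ester-bearing ring stands apart or why the other three rings lie so close. Still open, from the compounds shown here alone, is whether a morpholin-4-yl ring, an open-chain dimethylamino group, or a butyl chain in place of the propyl chain would shift the number in this assay, and whether a carboxylic acid in place of the ethyl ester would behave like compound 3.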